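Triazole Aryl Swap: Compound 4 Expected at the Limit

The source may hold more compounds than are shown below. What is called first, only, known or untested is meant among the compounds shown, and "the series" means these compounds.

Compound 1, `Cc1cccc(-n2nncc2CN2C(=O)C3(C(C#N)=C(N)Oc4c(N)cc5nc6ccccc6nc5c43)c3ccccc32)c1`, in an ADME assay on HUVEC cells (Homo sapiens) for antiproliferative activity, read by MTT assay, with a stated time of 48 h (a lower number here means a stronger inhibitor, a higher number a weaker inhibitor), gives > 50000 nM, a limit of the assay.
Compound 2, `CCc1cccc(C)c1-n1nncc1CN1C(=O)C2(C(C#N)=C(N)Oc3c(N)cc4nc5ccccc5nc4c32)c2ccccc21`, in this assay gives > 50000 nM, a limit of the assay.
Compound 3, `COc1ccc(OC)c(-n2nncc2CN2C(=O)C3(C(C#N)=C(N)Oc4c(N)cc5nc6ccccc6nc5c43)c3ccccc32)c1`, in this assay gives > 50000 nM, a limit of the assay.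

Compound 3 therefore stands at the limit rather than at a number, and the same holds for the other two compounds shown, since (the limit of > 50000 nM in this assay, at which 3 of the 3 values shown sit). The three steps among them, a step that the two limits leave unreadable from compound 1 to compound 2, a step that the two limits leave unreadable from compound 1 to compound 3 and a step that the two limits leave unreadable from compound 2 to compound 3, are all unreadable for this reason: two limits give no size.

Compound 4, `N#CC1=C(N)Oc2c(N)cc3nc4ccccc4nc3c2C12C(=O)N(Cc1cnnn1-c1ccc(F)c(Cl)c1)c1ccccc12`, differs from compound 3 by 3-chloro-4-fluorophenyl in place of 2,5-dimethoxyphenyl on an aromatic nitrogen. Going by the values given here, the only measured steps that bear on this change are the three aryl swaps on the same aromatic nitrogen, and none of them yields a readable size; each swap left the value at the limit.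

On that basis no step beyond the scatter can be foreseen in this assay, in either direction, and the expectation is that compound 4 also comes back as a limit. The estimate for compound 4 is 80000 nM, with a range from 30000 nM to 300000 nM, which means an expected step that the limit leaves unreadable from compound 3 to compound 4.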

Compound 4, half-maximal inhibitory concentration: > 50000 nM
Compound 4 gave a limit, no number (the forecaster's own chance of this, stated with the estimate: 85%); the middle value does not contradict the limit.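

Compound 4 also stands at a limit in this assay, so its steps from compound 1, compound 2 and compound 3 cannot be read, and no new step size can be stated: the limit of > 50000 nM in this assay, at which 4 of the 4 values shown sit.

The compounds shown leave open whether any of these four aryl groups on the aromatic nitrogen differs from the others in this activity, with no number among them to compare.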